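Swapping Ethyl for Cyclopropyl in Compound 3

The source may hold more compounds than are shown below. What is called first, only, known or untested is meant among the compounds shown, and "the series" means these compounds.

Of the compounds shown here, two have been measured so far in an ADME assay on cells for inhibition of cytochrome P450 11B1, mitochondrial (Homo sapiens), read by HTRF; a lower number here means a stronger inhibitor, a higher number a weaker inhibitor. Compound 1 (`CCC1c2cc(Cl)ccc2C(=O)N1c1cccnc1`) gives 3340 nM, and compound 2 (`CC(=O)N[C@@H]1CCCc2c1cncc2N1Cc2cc(Cl)ccc2C1=O`) gives 2330 nM. Compound 1 stands at the higher of these two numbers, but its gap to compound 2 lies within the usual scatter, so the two cannot be placed in order on this evidence.

Compound 3 (`O=C1c2ccc(Cl)cc2C(C2CC2)N1c1cccnc1`) has not yet been measured in this assay. Relative to compound 1 it carries a single change: cyclopropyl in place of ethyl on a saturated ring carbon. No measured pair among these compounds shows what such a swap does, so there is no step from which a direction could be read. With only that to go on, compound 3 is expected to land close to compound 1, and the estimated step of a 1.2-fold lower number from compound 1 to compound 3 (0.09 log units; within the scatter) is expected to stay within the scatter rather than point clearly up or down. Compound 3 is therefore estimated at 2700 nM in this assay, within a range from 900 nM to 8000 nM.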

Compound 3, half-maximal inhibitory concentration: 32500 nM
For compound 3 the middle estimate is 12-fold (1.08 log units) below the measured one; measured number above the stated range.
By their numbers in this assay, from the lowest: compounds 2 and 1 (each within the scatter of the next); then compound 3.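

In this assay, the saturated ring carbon next to the ring nitrogen proves sensitive to the group it carries: cyclopropyl in place of ethyl gives a 9.7-fold higher number from compound 1 to compound 3 (0.99 log units; beyond the scatter), a move toward weaker inhibition. For the compounds shown here, the earlier compounds could not show this, as no measured pair among them differed in one place, so this is the first reading of any single change on the core of compound 1. Nothing available here explains the size or direction of this step.

A single pair does not separate the effect of the three-membered ring from that of going from 2 heavy atoms to 3, and an isopropyl or a straight propyl chain on the same carbon would be needed to tell these apart. From the compounds shown here alone, it also remains open whether a smaller methyl group or a group bearing an amine or a hydroxyl on this carbon would keep the number near that of compound 1, and whether the same swap would give a step of similar size on another core.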